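From methyl to dimethylamino on a shared core

The compounds below may be only part of what the source reports. "The series", "measured", "known", "first", "only" and "open" are said of these compounds alone.

In an ADME assay on MRC5 cells (Homo sapiens) for cytotoxicity, read by neutral red uptake (on this read-out higher numbers stand for lower toxicity in this test and lower numbers for higher toxicity in this test), compound 1 `O=c1[nH]c(SCc2cc([N+](=O)[O-])cc([N+](=O)[O-])c2)nc2ccccc12` gives > 64000 nM and this is a limit of the assay and not a number. Compound 2 `O=c1[nH]c([S+]([O-])Cc2cc([N+](=O)[O-])cc([N+](=O)[O-])c2)nc2ccccc12` gives > 64000 nM and that too is only a limit. Compound 3 `Cc1ccc2nc(SCc3cc([N+](=O)[O-])cc([N+](=O)[O-])c3)[nH]c(=O)c2c1` gives > 64000 nM and that is again a limit. Compound 3 therefore has no exact number of its own. It shares the limit of > 64000 nM in this assay, at which 3 of the 3 values shown sit, and no order can be drawn among the three.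

The next compound to be tested is compound 4 `CN(C)c1ccc2nc(SCc3cc([N+](=O)[O-])cc([N+](=O)[O-])c3)[nH]c(=O)c2c1` which carries dimethylamino in place of methyl on an aromatic carbon. The counted difference is dimethylamino in place of methyl on an aromatic carbon and the rest of the structure stays the same.

Among the measured compounds shown here, only one measured step bears on this change. It swaps in methyl in place of hydrogen on an aromatic carbon and appears as a step that the two limits leave unreadable from compound 1 to compound 3 so it offers no size to carry forward. With no readable step to go on, no shift beyond the usual scatter is expected in this assay and in either direction, and another limit would be no surprise. The expected step is a number no higher from compound 3 to compound 4 (the limit leaves the size open) as an estimate only. Compound 4 is estimated at 64000 nM with an expected range from 30000 nM to 128000 nM for its measurement.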

Compound 4, half-maximal cytotoxic concentration: 14000 nM
The estimate for compound 4 lay 4.6-fold (0.66 log units) above the measured number; measured number outside the range, below it.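

In this assay, the group on this aromatic carbon of the shared core can clearly change the read-out, which the earlier swap of hydrogen for methyl could not show, since that step cannot be read. Dimethylamino in place of methyl gives an at least 4.5-fold lower number from compound 3 to compound 4 (0.66 log units; beyond the scatter), and dimethylamino in place of hydrogen gives an at least 4.5-fold lower number from compound 1 to compound 4 (0.66 log units; beyond the scatter), so in this test the dimethylamino compound is the more toxic in both comparisons. Compound 4 is also the only compound shown with an exact number, and so the only one that gives later changes a measured point to be compared against, while the others remain at a limit of the assay: the limit of > 64000 nM in this assay, at which 3 of the 4 values shown sit.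

The compounds shown cannot separate the nitrogen of dimethylamino from its larger count of heavy atoms as the source of this step. A plain amino group, a methoxy group or a longer chain such as diethylamino on the same aromatic carbon would help to tell these apart, by showing whether the number falls with any larger group or only with an amine.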